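The compounds below may be only part of what the source reports. "The series", "measured", "known", "first", "only" and "open" are said of these compounds alone.

For the measured compounds named here, compound 1 `CN(C)CCCOc1ccc(Nc2nccc(-c3cccnc3)n2)cc1` gives 600 nM in a functional assay for inhibition, with Homo sapiens as the target (a lower number here means a stronger inhibitor, a higher number a weaker inhibitor), the lowest of the three numbers measured so far. Compound 3 `COc1ccccc1Nc1nccc(-c2cccnc2)n1` gives 9800 nM in this assay, and compound 2 `Cc1cccc(Nc2nccc(-c3cc(C)oc3C)n2)c1` gives 28500 nM; both gaps from compound 1 lie beyond the scatter. Compound 4 `CC(=O)Nc1ccc(Nc2nccc(-c3cccnc3)n2)cc1` has not yet been measured. It differs from compound 1 in one place: acetamido in place of 3-(dimethylamino)propoxy on an aromatic carbon. Going by the values given here, no measured pair shows this change, so its size is unknown; the expectation is a shift toward a higher number, beyond the scatter, yet smaller than the gap to compound 3, whose value 9800 nM reflects a different change. The estimated step is a 4.2-fold higher number from compound 1 to compound 4 (0.62 log units; beyond the scatter). Compound 4 is expected to give about 2500 nM in this assay, within 600 nM to 10000 nM.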

Compound 4, half-maximal inhibitory concentration: 3600 nM
Compound 4: the middle estimate sits 1.4-fold (0.16 log units) below what was measured; the range from low to high includes it.
By their numbers in this assay, from the lowest: compound 1; then compound 4; then compound 3; then compound 2.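

Swapping 3-(dimethylamino)propoxy for acetamido on this aromatic carbon, para to a large group, gives a 6.0-fold higher number from compound 1 to compound 4 (0.78 log units; beyond the scatter) in this assay. For the compounds shown here, this is the first single-place comparison, and it shows that the group at this position moves the number by a modest step beyond the scatter, while activity remains measurable with the shorter acetamido. Nothing available explains the direction of this step.

Going by these compounds alone, the single step does not separate the contributions of chain length, the terminal amine and the amide. A shorter 2-(dimethylamino)ethoxy chain, a primary amine or a carboxylic acid at this position would bear on that.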